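Cyclohexyl in Place of Cyclopentyl on the Oxygen

A few compounds are considered here, and "the series" means these few. Any claim that something is new, unique, unknown or untested is made for them only; others in the source may bear on it.

In a functional assay on SH-SY5Y cells (Homo sapiens) for antagonist activity, read by cAMP accumulation (a higher number here means a more potent compound, by a factor of ten per unit of this negative logarithm, a lower number a less potent compound), compound 1 (`CCCCCCOc1ccc(Cc2ccc(NC3=NCCN3)cc2)cc1`) gives 8.2, while compound 2 (`c1cc(NC2=NCCN2)ccc1Cc1ccc(OC2CCCC2)cc1`) gives 8.9, the higher of the two numbers. Compound 3 (`c1cc(NC2=NCCN2)ccc1Cc1ccc(OC2CCCCC2)cc1`) has not yet been measured. It differs from compound 2 at a single place: cyclohexyl in place of cyclopentyl on an oxygen on an aromatic ring, with cyclohexyl in place of cyclopentyl on an oxygen on an aromatic ring.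

Going by the values given here, only one measured step bears on this change. At the same place, cyclopentyl in place of hexyl gave a number 0.70 log units higher from compound 1 to compound 2 (beyond the scatter). That step replaced a chain with a ring, whereas here one ring replaces another, so a smaller change is expected in this assay, slightly downward if anything. The expected step is a number 0.10 log units lower from compound 2 to compound 3 (within the scatter), which is estimated to lie within the scatter. For compound 3 the estimated value is 8.8, with an expected range from 8.4 to 9.2.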

Compound 3, negative logarithm of the antagonist equilibrium constant: 8.6
Beside the measured number, compound 3's estimate is 0.20 log units above it; the measured number falls inside the stated range.
By their numbers in this assay, from the lowest: compound 1; then compounds 3 and 2 (each within the scatter of the next).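

Replacing cyclopentyl with cyclohexyl on the oxygen gives a number 0.30 log units lower from compound 2 to compound 3 (within the scatter) in this assay and so the two rings cannot be told apart at this position. The gain over the hexyl chain is therefore not confined to cyclopentyl, since cyclohexyl also gives a number 0.40 log units higher from compound 1 to compound 3 (beyond the scatter) in the same assay. Nothing available explains either step.

The compounds shown leave open whether a smaller ring such as cyclobutyl, or a branched chain such as isopropyl, would fit the same picture on this oxygen. They also leave open what an amine or a carboxylic acid on the cyclohexyl ring would do, and whether the two rings stay indistinguishable when the rest of the core is changed.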